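Removing one methyl from the pyrazole of compound 1

This account rests on a few compounds, and the source may have more. Where it says the series, first, only, none or still open, it means among the compounds named here.

Measured so far:
Compound 1 `Cc1n[nH]c(C)c1-c1cncc(-c2ccc(C(N)=O)c(OC(C)C)c2)c1`: 33 nM
Compound 2 `NC(=O)c1ccc(-c2ccc(N)nc2)cc1`: 34000 nM
Compound 3 `CC(C)Oc1cc(-c2cncc(-c3cnn(C4CCOC4)c3)c2)ccc1C(N)=O`: 120 nM

In an assay on cells for inhibition of MAP kinase-interacting serine/threonine-protein kinase 1 (Homo sapiens), read by mobility shift assay, with stated times of 10 min and 60 min, in the presence of a further agent that is not named here (a lower number here means a stronger inhibitor, a higher number a weaker inhibitor), compound 1 gives 33 nM, the lowest of the three numbers. The nearest number is that of compound 3, which in this assay gives 120 nM, and the furthest is that of compound 2, which in this assay gives 34000 nM; both gaps to compound 1 lie beyond the scatter.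

Compound 4 `Cc1[nH]ncc1-c1cncc(-c2ccc(C(N)=O)c(OC(C)C)c2)c1` has not yet been measured. It differs from compound 1 in one place: hydrogen in place of methyl on an aromatic carbon. The larger pattern that compound 1 and compound 3 share, with the isopropoxy-bearing carboxamide arm on the shared core, is kept; only the pyrazole is trimmed.

For the measured compounds named here, no two measured compounds differ in exactly this way, so the size of the step rests on expectation alone. The change is small, and in this assay the step of a 2.1-fold higher number from compound 1 to compound 4 (0.33 log units; beyond the scatter) is expected to be a modest weakening, at the edge of the scatter. Compound 4 is therefore estimated at 70 nM, in a range from 25 nM to 250 nM.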

Compound 4, half-maximal inhibitory concentration in the MAP kinase-interacting serine/threonine-protein kinase 1 assay: 54 nM
The estimate for compound 4 lay 1.3-fold (0.11 log units) above the measured number; the range from low to high includes it.
By their numbers in the MAP kinase-interacting serine/threonine-protein kinase 1 assay, from the lowest: compounds 1 and 4 (each within the scatter of the next); then compound 3; then compound 2.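

Going from 3,5-dimethyl-1H-pyrazol-4-yl to 5-methyl-1H-pyrazol-4-yl gives the only one-place step among the compounds shown, and in the MAP kinase-interacting serine/threonine-protein kinase 1 assay it reads a 1.6-fold higher number from compound 1 to compound 4 (0.21 log units; within the scatter), so the methyl at this position can be replaced by hydrogen without a difference that rises above the scatter. The same holds for solubility: in a physicochemical assay for solubility, measured as thermodynamic solubility, at pH 7.4 (on this read-out higher numbers stand for higher solubility and lower numbers for lower solubility), compound 1 gives 10 ug/mL and compound 4 gives 11 ug/mL, which is a 1.1-fold higher number from compound 1 to compound 4 (0.04 log units; within the scatter). Nothing available here offers an explanation for either result.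

The compounds shown leave open whether a larger group on this aromatic carbon, such as an ethyl or an aminomethyl, would stay within the scatter in the MAP kinase-interacting serine/threonine-protein kinase 1 assay. They also leave open what hydrogen in place of the remaining methyl would do.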